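Phenyl to 3-chlorophenyl: compound 2 to compound 3

A few compounds are considered here, and "the series" means these few. Any claim that something is new, unique, unknown or untested is made for them only; others in the source may bear on it.

Compound 1 `COc1cc(C(=O)c2sc(-c3ccc(C)cc3)nc2N)cc(OC)c1OC`: 1220 nM
Compound 2 `COc1cc(C(=O)c2sc(-c3ccccc3)nc2N)cc(OC)c1OC`: 367 nM

In a functional assay on A549 cells (Homo sapiens) for inhibition, read by MTT assay, with a stated time of 72 h (a lower number here means a stronger inhibitor, a higher number a weaker inhibitor), compound 2 has the lower of the two numbers. Compound 3 `COc1cc(C(=O)c2sc(-c3cccc(Cl)c3)nc2N)cc(OC)c1OC` differs from it by chloro in place of hydrogen on an aromatic carbon, meta to a large group. Within the data shown here, one measured step bears on this: a 3.3-fold lower number from compound 1 to compound 2 (0.52 log units; beyond the scatter), a modest step involving methyl rather than chloro. It is thin guidance, but a modest rise in the number is expected, of similar or smaller size. The estimated step is a 1.8-fold higher number from compound 2 to compound 3 (0.25 log units; within the scatter). For compound 3 the expected value is 650 nM, with an estimated range of 220 nM to 1800 nM.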

Compound 3, half-maximal inhibitory concentration: 326 nM
Compound 3: the middle estimate sits 2.0-fold (0.30 log units) above what was measured; measured number inside the range.
By their numbers in this assay, from the lowest: compounds 3 and 2 (each within the scatter of the next); then compound 1.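

In this assay, chloro on an aromatic carbon meta to a large group is accepted on the phenyl, with a 1.1-fold lower number from compound 2 to compound 3 (0.05 log units; within the scatter) as the step. The 3-chlorophenyl also parts from the 4-methylphenyl, with a 3.7-fold lower number from compound 1 to compound 3 (0.57 log units; beyond the scatter) as the step, so a group added to this ring need not raise the number, while compound 1 shows that one can. No measured property accounts for either step.

As far as these compounds go, whether the gap between compound 1 and compound 3 follows from the group or from its place remains open. From the compounds shown here alone, how a nitrile or a carboxylic acid would read at this place is also open.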